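Nitrile for methyl on the pyridine of a fluorinated alkyne

The compounds below may be only part of what the source reports. "The series", "measured", "known", "first", "only" and "open" are said of these compounds alone.

Measured so far:
compound 1 `N#Cc1cccc(C#Cc2cccc(C#N)n2)c1`: 8.2 nM
compound 2 `Cc1cccc(C#Cc2cc(F)cc(C#N)c2)n1`: 0.67 nM

Among the measured compounds shown here, in an assay on membranes from brain (strain Sprague-Dawley) for displacement of a labelled ligand from metabotropic glutamate receptor 5 (Rattus norvegicus), read by scintillation counting, with a stated time of 60 min (a higher number here means a weaker inhibitor, a lower number a stronger inhibitor), compound 2 gives the lower of the two numbers, with compound 1 the only neighbour and its value well beyond the scatter above it. Compound 3 `N#Cc1cc(F)cc(C#Cc2cccc(C#N)n2)c1` is not yet measured; it carries cyano in place of methyl on an aromatic carbon. Compound 1 also carries a nitrile at this carbon and is the weaker of the pair, so the step from compound 2 to compound 3 is expected to raise the number, beyond the scatter a 4.5-fold higher number from compound 2 to compound 3 (0.65 log units; beyond the scatter). For compound 3 the expected value is 3 nM, within 1 nM to 10 nM.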

Compound 3, inhibition constant: 2.7 nM
Beside the measured number, compound 3's estimate is 1.1-fold (0.05 log units) above it; the range from low to high includes it.
By their numbers in this assay, from the lowest: compound 2; then compound 3; then compound 1.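

In this assay, cyano in place of methyl on the carbon next to the ring nitrogen gives a 4.0-fold higher number from compound 2 to compound 3 (0.61 log units; beyond the scatter), so with fluoro held constant, methyl gives the lower number of the two groups at this position. Fluoro in place of hydrogen gives a 3.0-fold lower number from compound 1 to compound 3 (0.48 log units; beyond the scatter), which shows that fluoro lowers the number with the nitrile present. Nothing available explains either step.

Open, from the compounds shown here alone, is whether fluoro has a similar effect when methyl occupies this position. Also open, going by these compounds, is how a chloro, methoxy or amino group here would compare with methyl and cyano.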